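Side-chain swap on compound 3: clearance notes

The compounds below may be only part of what the source reports. "The series", "measured", "known", "first", "only" and "open" are said of these compounds alone.

Measured in an in vitro ADME assay on microsomes from liver (Homo sapiens) for metabolic stability, using NADPH; a lower number here means slower removal, a higher number faster removal of the compound:
- compound 1 `CC(C)(CO)CNC(=O)c1cc2cc(C#N)ccc2n1Cc1cccc(OC(F)(F)F)c1` gives 62 mL.min-1.g-1
- compound 2 `Cc1ccc(C)c(Cn2c(C(=O)NCC(C)(C)CO)cc3cc(C#N)ccc32)c1` gives 257 mL.min-1.g-1
- compound 3 `N#Cc1ccc2c(c1)cc(C(=O)NCCC(O)C(F)(F)F)n2Cc1cccc(OC(F)(F)F)c1` gives 59 mL.min-1.g-1

Compound 3 sits level with compound 1 within the scatter, while compound 2 carries the clearly higher number. The next structure is compound 4 `N#Cc1ccc2c(c1)cc(C(=O)NCCC1(O)CCC1)n2Cc1cccc(OC(F)(F)F)c1` and the change is 1-hydroxycyclobutyl in place of 2,2,2-trifluoro-1-hydroxyethyl on a saturated chain carbon, two bonds along the chain from an amide-type nitrogen in the form of 1-hydroxycyclobutyl in place of 2,2,2-trifluoro-1-hydroxyethyl on a saturated chain carbon. For the measured compounds named here, the one measured step bearing on this is a 1.1-fold lower number from compound 1 to compound 3 (0.02 log units; within the scatter) and it also replaces the side chain alone. Compound 1 holds no fluorine in that chain, yet its value stays within the scatter of compound 3. The data contain no direct measurement of the cyclobutyl ring. What is expected is a 1.3-fold higher number from compound 3 to compound 4 (0.10 log units; within the scatter) and so no step beyond the scatter, with a slight upward lean allowed for the untested ring. The estimated value of compound 4 is 75 mL.min-1.g-1 with an expected range from 35 mL.min-1.g-1 to 160 mL.min-1.g-1 on this measure.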

Compound 4, intrinsic clearance in microsomes: 78 mL.min-1.g-1
Compound 4: the middle estimate sits 1.0-fold (0.02 log units) below what was measured, and the stated range covers the measured number.
By their numbers in this assay, from the lowest: compounds 3, 1 and 4 (each within the scatter of the next); then compound 2.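

In this assay, 1-hydroxycyclobutyl in place of 2,2,2-trifluoro-1-hydroxyethyl gives a 1.3-fold higher number from compound 3 to compound 4 (0.12 log units; within the scatter), so at this place, on a saturated chain carbon two bonds along the chain from an amide-type nitrogen, a four-membered carbon ring can replace the fluorinated group without a step beyond the scatter. The comparison with the open-chain alcohol reads the same, with a 1.3-fold higher number from compound 1 to compound 4 (0.10 log units; within the scatter), so all three hydroxyl-bearing side chains on the shared core now lie within the scatter of one another. Nothing available explains this flat response.

On these data alone, all three of these side chains keep a hydroxyl, so it remains open whether an amine, a carboxylic acid or a longer chain in its place would give a step beyond the scatter. As far as these compounds go, it also remains open whether the (1-hydroxycyclobutyl)methyl side chain would behave the same way on the core of compound 2.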